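The compounds below may be only part of what the source reports. "The series", "measured", "known", "first", "only" and "open" are said of these compounds alone.

In a functional assay on HeLa cells (Homo sapiens) for antiproliferative activity, read by MTT assay, with a stated time of 72 h (a lower number here means a stronger inhibitor, a higher number a weaker inhibitor), compound 1 `CNc1nc(-c2cc(OC)c(OC)c(OC)c2)c(-c2ccc3ccccc3c2)s1` gives 128 nM and compound 2 `CNc1nc(-c2cc(OC)c(OC)c(OC)c2)c(-c2ccc(C)cc2)s1` gives 69.1 nM. These two values lie within the usual scatter of repeated measurements, so they cannot be ranked against each other. Compound 3 `COc1cc(-c2nc(N(C)C)sc2-c2ccc(C(F)(F)F)cc2)cc(OC)c1OC` reads > 10000 nM, which is a limit of the assay and not a number. Compound 1 therefore sits level with compound 2 among the two actual numbers available.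

The next compound, compound 4 `COc1cc(-c2nc(C)sc2-c2ccc3ccccc3c2)cc(OC)c1OC`, has methyl in place of methylamino on an aromatic carbon. This swap removes a hydrogen-bond donor from the compound. Among the measured compounds shown here, no two measured compounds here differ in one place only, so no measured step shows what this kind of swap does in this assay. The expectation is therefore a tentative one: a moderate rise in the number, meaning a somewhat weaker inhibitor, with a real chance of no change beyond the scatter. The estimated change is a 3.1-fold higher number from compound 1 to compound 4 (0.49 log units; beyond the scatter). For compound 4 the expected value is 400 nM, with an estimated range from 80 nM to 4000 nM.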

Compound 4, half-maximal inhibitory concentration: 82.1 nM
Beside the measured number, compound 4's estimate is 4.9-fold (0.69 log units) above it, within the range that was stated.
By their numbers in this assay, from the lowest: compounds 2, 4 and 1 (each within the scatter of the next). At a limit, above all of these: compound 3.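

In this assay, among the compounds shown here, the swap of methylamino for methyl gives a 1.6-fold lower number from compound 1 to compound 4 (0.19 log units; within the scatter) and so offers the first measured step at this position on the five-membered aromatic ring. Compound 4 has neither the hydrogen-bond donor nor the hydrogen-bond acceptor counted for methylamino, yet this pair shows no change that can be told from the scatter, so for this pair that donor is not needed to keep the number in the range of compound 1. The data shown hold no measurement that accounts for this small step.

Going by these compounds, this reading rests on one pair with the same large groups elsewhere on the core, so it remains open whether the swap would behave the same way on compound 2, which carries a different group on the ring. On these data alone, it also remains open how this position responds to groups other than these two, such as a plain amino group, a hydroxyl group or a longer chain such as propyl, so the range of groups tolerated here cannot yet be drawn.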